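Dropping the 4-chlorophenyl from compound 2

The compounds below may be only part of what the source reports. "The series", "measured", "known", "first", "only" and "open" are said of these compounds alone.

In a functional assay on L1210 cells (Mus musculus) for inhibition, read by cell counting, with a stated time of 48 h (on this read-out lower numbers stand for stronger inhibition and higher numbers for weaker inhibition), compound 2 `CCN(CC)CN1C(=O)/C(=N/NC(=S)Nc2ccc(Cl)cc2)c2ccccc21` gives 11000 nM, the lower of the two actual numbers, and compound 1 `CCN(CC)CN1C(=O)/C(=N/NC(=S)Nc2ccccc2)c2cc(Cl)ccc21` gives 49000 nM. Compound 3 `CCN(CC)CN1C(=O)/C(=N/NC(=S)Nc2ccc(Cl)cc2)c2cc(Cl)ccc21` reaches only a limit, > 125000 nM. Compound 4 `CCN(CC)CN1C(=O)/C(=N/NC(N)=S)c2ccccc21` carries hydrogen in place of 4-chlorophenyl on an amide-type nitrogen. Going by the values given here, no measured step removes that group. The nearest evidence is chloro in place of hydrogen on an aromatic carbon, which gives an at least 2.5-fold higher number from compound 1 to compound 3 (0.40 log units; beyond the scatter) and a large at least 11-fold higher number from compound 2 to compound 3 (1.05 log units; beyond the scatter). Both steps raise the number, so compound 2 appears sensitive to a single change. The expected change in this assay is a 2.7-fold higher number from compound 2 to compound 4 (0.44 log units; beyond the scatter), a clear rise beyond the scatter. Compound 4 is estimated at 30000 nM, with an expected range of 8000 nM to 110000 nM.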

Compound 4, half-maximal inhibitory concentration: 121000 nM
Compound 4: the middle estimate sits 4.0-fold (0.61 log units) below what was measured, and the stated range ends below it.
By their numbers in this assay, from the lowest: compound 2; then compound 1; then compound 4. At a limit, above all of these: compound 3.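

In this assay, hydrogen in place of 4-chlorophenyl on an amide-type nitrogen gives an 11-fold higher number from compound 2 to compound 4 (1.04 log units; beyond the scatter). The earlier steps shown here covered only chloro in place of hydrogen on an aromatic carbon, whereas this one shows that the group on this nitrogen matters too, and that in this pair the 4-chlorophenyl goes with the lower number. Removing it places compound 4 close to the top of the measurable range: the limit of > 125000 nM in this assay, at which 1 of the 4 values shown sits.

Open, going by these compounds, is whether the whole ring is needed or whether a smaller group, such as methyl, would serve on this nitrogen. Also open, on these data alone, is how an unsubstituted phenyl or a benzyl there would read on the core of compound 2.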